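This account rests on a few compounds, and the source may have more. Where it says the series, first, only, none or still open, it means among the compounds named here.

Of the compounds shown here, three with a shared core have numbers so far in a functional assay on MCF7 cells (Homo sapiens) for antiproliferative activity, read by MTT assay, with a stated time of 72 h; on this read-out lower numbers stand for stronger inhibition and higher numbers for weaker inhibition: compound 1 (`CCOc1ccc(-c2ccc3ncn(-c4cc(OC)c(OC)c(OC)c4)c3c2)cc1`) gives 1710 nM, compound 2 (`COc1cc(-n2cnc3ccc(-c4cccc(Cl)c4)cc32)cc(OC)c1OC`) gives 3120 nM, and compound 3 (`COc1cc(-n2cnc3ccc(-c4cccc(C)c4C)cc32)cc(OC)c1OC`) gives 2150 nM. Compound 3 cannot be separated from the other two on these numbers, with a 1.3-fold higher number from compound 1 to compound 3 (0.10 log units; within the scatter) and a 1.5-fold lower number from compound 2 to compound 3 (0.16 log units; within the scatter).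

Compound 4 (`COc1cc(-n2cnc3ccc(-c4ccc(F)cc4)cc32)cc(OC)c1OC`) carries 4-fluorophenyl in place of the 2,3-dimethylphenyl of compound 3 on an aromatic carbon, and the rest of the structure is unchanged: 4-fluorophenyl in place of 2,3-dimethylphenyl on an aromatic carbon.

All three measured steps bear on this change, since each exchanges one substituted phenyl group for another on that same carbon. None leaves the scatter, including a 1.8-fold higher number from compound 1 to compound 2 (0.26 log units; within the scatter). Among the measured compounds shown here, the 4-fluorophenyl group itself has not yet been measured, so these steps are indirect evidence, and they cover only three compounds. They give no direction for the new exchange, and no step beyond the scatter is expected in this assay. The expected change is a 1.1-fold higher number from compound 3 to compound 4 (0.03 log units; within the scatter), a small estimated step with no firm direction. For compound 4 the estimate is 2300 nM, with an expected range from 1100 nM to 4800 nM.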

Compound 4, half-maximal inhibitory concentration: 1770 nM
Beside the measured number, compound 4's estimate is 1.3-fold (0.11 log units) above it, within the range that was stated.
By their numbers in this assay, from the lowest: compounds 1, 4, 3 and 2 (each within the scatter of the next).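

In this assay the 4-fluorophenyl group does not separate from any other substituted phenyl group on this aromatic carbon, with a 1.2-fold lower number from compound 3 to compound 4 (0.08 log units; within the scatter) and a 1.8-fold lower number from compound 2 to compound 4 (0.25 log units; within the scatter) and also a 1.0-fold higher number from compound 1 to compound 4 (0.01 log units; within the scatter) on the record for this change. A fluoro substituent on the phenyl ring therefore joins ethoxy, chloro and two methyl groups with no step beyond the scatter, so the flat picture from the earlier three compounds now holds across four, including an exchange in which the entering and leaving groups both have one six-membered aromatic ring of carbon only, no hydrogen-bond donors or acceptors and no net charge. No measurement is available that could explain why these exchanges leave the numbers so close.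

All the groups shown at this carbon are substituted phenyl rings, so the compounds leave open whether a phenyl ring carrying an amine or a carboxylic acid, or a pyridine ring in place of the phenyl ring, would give a step beyond the scatter. They also leave open whether any change to the shared core away from this carbon would do so.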